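The source may hold more compounds than are shown below. What is called first, only, known or untested is meant among the compounds shown, and "the series" means these compounds.

The measured compounds in this study:

Compound 1 `C=C(CC)C(=O)c1ccc(OCC(=O)NCC(=O)O)c(Cl)c1Cl`: in a functional assay on CLL cells (Homo sapiens) for cytotoxicity, read by MTT assay, with a stated time of 48 h (on this read-out higher numbers stand for an effect only at larger amounts of compound and lower numbers for an effect already at smaller amounts), compound 1 gives > 25000 nM.
Compound 2 `C=C(CC)C(=O)c1ccc(OCC(=O)Nc2ccc(O)c([N+](=O)[O-])c2)c(Cl)c1Cl`: in this assay compound 2 gives 7400 nM.
Compound 3 `C=C(CC)C(=O)c1ccc(OCC(=O)Nc2ccc3c(c2)C(O)N=NC3O)c(Cl)c1Cl`: in this assay compound 3 gives 8500 nM.

Going by the values given here, compound 1 stands apart from the other two in that its result is a limit of the assay and not a number; it is the one compound of the three that sits there (the limit of > 25000 nM in this assay, at which 1 of the 3 values shown sits). Compound 2 and compound 3 give numbers that lie within the usual scatter of each other, so no order between them can be read. Among the compounds with values here, no two of the measured compounds differ from each other in a single place, and therefore no measured step is available.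

Compound 4 `C=C(CC)C(=O)c1ccc(OCC(=O)NO)c(Cl)c1Cl` is the unmeasured compound, and it differs from compound 1 in one place: hydroxy in place of carboxymethyl on an amide-type nitrogen Read one bond further out, (carboxymethyl)carbamoyl becomes hydroxycarbamoyl.

With compound 1 known only as a limit, the size of the step cannot be anchored on a number. The author expects a gain for compound 4 over compound 1 of about an at least 1.6-fold lower number from compound 1 to compound 4 (0.22 log units; that floor lies within the scatter), bringing compound 4 toward the range of compound 2 and compound 3, though a second limit remains a real possibility. For compound 4 the estimated value in this assay is 15000 nM, with a range from 4000 nM to 40000 nM.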

Compound 4, half-maximal effective concentration: 4500 nM
For compound 4 the middle estimate is 3.3-fold (0.52 log units) above the measured one; the range from low to high includes it.
By their numbers in this assay, from the lowest: compounds 4, 2 and 3 (each within the scatter of the next). At a limit, above all of these: compound 1.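

In this assay, going by these compounds alone, exchanging carboxymethyl for hydroxy on the amide-type nitrogen, with the rest of the molecule unchanged, gives the first step that can be read between two compounds differing in one place: an at least 5.5-fold lower number from compound 1 to compound 4 (0.74 log units; beyond the scatter). The earlier compounds shown here could not show this, as none of them differed from another in a single place, so the group on this nitrogen could not be judged on its own. Here, that one change is enough to carry the read-out beyond the usual scatter, although compound 1 remains a limit and not a number, so the step has a floor but no known size: the limit of > 25000 nM in this assay, at which 1 of the 4 values shown sits.

The compounds shown leave open whether the gain depends on the hydroxy itself or simply on the departure of carboxymethyl, a question that a methoxy group, a methyl group or a plain amide hydrogen on the same nitrogen would address. They also leave open how a longer chain ending in a carboxylic acid, or a short chain ending in an amine, would read at this position.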